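Half-life notes: indanyl amide in place of cyclopentyl

The source may report more compounds than this note shows. Statements on the series, on what has been measured and on what is new or still open speak of the compounds shown alone.

Measured so far:
compound 1 `C[C@@H]1CC[C@@H](O)[C@H]1NC(=O)[C@H](Cc1ccccc1)C[C@H](O)CN1CCN(Cc2cccnc2)C[C@H]1C(=O)NC(C)(C)C` — 0.525 h
compound 2 `CC(C)(C)NC(=O)[C@@H]1CN(Cc2cccnc2)CCN1C[C@@H](O)C[C@@H](CC1CCCCC1)C(=O)N[C@H]1c2ccccc2C[C@H]1O` — 0.907 h

In an ADME assay on the whole organism for pharmacokinetics, with Canis familiaris (Canis lupus familiaris) as the target (a higher number here means that the compound lasts longer, a lower number that the compound disappears faster), compound 1 gives 0.525 h; compound 2 gives 0.907 h, a number that lies within the usual scatter of the value of compound 1. Compound 3 `CC(C)(C)NC(=O)[C@@H]1CN(Cc2cccnc2)CCN1C[C@@H](O)C[C@@H](Cc1ccccc1)C(=O)N[C@H]1c2cccc(Cl)c2C[C@H]1O` is not yet measured. It differs from compound 1 as follows: 4-chloro-2-hydroxy-2,3-dihydro-1H-inden-1-yl in place of 2-hydroxy-5-methylcyclopentyl on an amide-type nitrogen. Among the measured compounds shown here, no measured pair isolates this change. In this assay the step is expected to be small, if anything toward a longer half-life, because compound 2 gives 0.907 h. Compound 3 is estimated at 0.7 h, with an expected range from 0.35 h to 1.4 h. This corresponds to an expected step of a 1.3-fold higher number from compound 1 to compound 3 (0.12 log units; within the scatter).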

Compound 3, half-life: 0.763 h
Estimate against measurement, compound 3: 1.1-fold (0.04 log units) below; low and high end bracket the measured number.
By their numbers in this assay, from the lowest: compounds 1, 3 and 2 (each within the scatter of the next).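

In this assay, among the compounds shown here, placing 4-chloro-2-hydroxy-2,3-dihydro-1H-inden-1-yl in place of 2-hydroxy-5-methylcyclopentyl on the amide-type nitrogen gives the first isolated step at this position, a 1.5-fold higher number from compound 1 to compound 3 (0.16 log units; within the scatter), and that step lies within the scatter. This position therefore accepts the larger group with its added aromatic ring without a separable difference in half-life. No measurement bearing on the origin of this result is available. Still open, as far as these compounds go, is whether fluoro or methoxy in place of the chlorine, or an amine in place of the hydroxyl, would give a step beyond the scatter.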